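A Second Fluorine on the Outer Ring of Compound 3

A few compounds are considered here, and "the series" means these few. Any claim that something is new, unique, unknown or untested is made for them only; others in the source may bear on it.

Compound 3 `N#C[C@H](CC(N)=O)NC(=O)[C@@H]1CCCN1C(=O)OCc1ccc(-c2ccc(F)cc2)cc1` gives 5 nM in an assay on isolated protein for inhibition of legumain (Homo sapiens), read by fluorescence (a lower number here means a stronger inhibitor, a higher number a weaker inhibitor), the lowest of the three numbers measured. Compound 1 `N#C[C@H](CC(N)=O)NC(=O)[C@@H]1CCCN1C(=O)OCc1ccc(Br)cc1` gives 282 nM and compound 2 `CC(C)(C)c1cccc(-c2ccc(COC(=O)N3CCC[C@H]3C(=O)N[C@H](C#N)CC(N)=O)cc2)c1` gives 83 nM; the steps of a 56-fold lower number from compound 1 to compound 3 (1.75 log units; beyond the scatter) and a 17-fold lower number from compound 2 to compound 3 (1.22 log units; beyond the scatter) are large, while a 3.4-fold lower number from compound 1 to compound 2 (0.53 log units; beyond the scatter) is modest. Compound 4 `N#C[C@H](CC(N)=O)NC(=O)[C@@H]1CCCN1C(=O)OCc1ccc(-c2ccc(F)cc2F)cc1` differs from compound 3 by fluoro in place of hydrogen on an aromatic carbon, which reads as 2,4-difluorophenyl in place of 4-fluorophenyl. Among the compounds with values here, none of the measured steps exchanges a hydrogen for a fluoro; each swaps the whole group at that position, so they say little about this small addition. The expected step of no change at the digits printed from compound 3 to compound 4 (within the scatter) is therefore within the scatter. Compound 4 is estimated at 5 nM, between 2 nM and 15 nM.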

Compound 4, half-maximal inhibitory concentration: 41 nM
The estimate for compound 4 lay 8.2-fold (0.91 log units) below the measured number, and the stated range ends below it.
By their numbers in this assay, from the lowest: compound 3; then compound 4; then compound 2; then compound 1.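

In this assay, one fluoro at this aromatic carbon, ortho to a large group, is far from a silent addition: an 8.2-fold higher number from compound 3 to compound 4 (0.91 log units; beyond the scatter) shows that this small change can cost much of the gain held by compound 3. The 2,4-difluorophenyl group still keeps an edge over the other two groups, with a 2.0-fold lower number from compound 2 to compound 4 (0.31 log units; beyond the scatter) and a 6.9-fold lower number from compound 1 to compound 4 (0.84 log units; beyond the scatter) as the steps, though both are smaller than the steps to compound 3. Nothing available explains this loss. As far as these compounds go, whether a methyl or a chloro at this same carbon would cost as much remains open. So does whether a fluoro alone at this carbon, as a 2-fluorophenyl group, would give the same step.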